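This account rests on a few compounds, and the source may have more. Where it says the series, first, only, none or still open, it means among the compounds named here.

Of the compounds shown here, two have been measured so far. In a functional assay on BT-474 cells (Homo sapiens) for antiproliferative activity, read by CCK-8 assay, with a stated time of 72 h (on this read-out higher numbers stand for weaker inhibition and lower numbers for stronger inhibition), compound 1 (`O=C(c1ccncc1)N1N=C(c2ccc(Cl)cc2)CC1c1ccco1`) gives 6500 nM and compound 2 (`COc1ccccc1C1=NN(C(=O)c2ccncc2)C(c2ccc([N+](=O)[O-])cc2)C1`) gives 7200 nM. These two values lie within the scatter of each other, so compound 2 stands level with compound 1 on the present numbers.

Compound 3 (`COc1ccccc1C1=NN(C(=O)c2ccc([N+](=O)[O-])o2)C(c2ccc([N+](=O)[O-])cc2)C1`) carries 5-nitrofuran-2-yl in place of pyridin-4-yl on a carbonyl carbon of compound 2: 5-nitrofuran-2-yl in place of pyridin-4-yl on a carbonyl carbon. Going by the values given here, no measured pair shows a change at this place, so the data give no direct guide to the size of the step. A moderate step toward stronger inhibition in this assay is expected, although a result within the scatter remains possible. The estimate corresponds to an expected step of a 3.3-fold lower number from compound 2 to compound 3 (0.51 log units; beyond the scatter). For compound 3 the estimated value is 2200 nM, with an expected range of 450 nM to 8500 nM.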

Compound 3, half-maximal inhibitory concentration: > 50000 nM
Compound 3: no number, only a limit; the forecaster's own chance of this, stated with the estimate: 5%; middle value at least 22-fold (1.35 log units) away from the limit.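

Going by these compounds alone, compound 3 gives the first single-place step, and it shows that the group on the carbonyl carbon is not interchangeable. In this assay, 5-nitrofuran-2-yl in place of pyridin-4-yl gives an at least 6.9-fold higher number from compound 2 to compound 3 (0.84 log units; beyond the scatter), a move toward weaker inhibition with the rest of compound 2 unchanged. Compound 3 has only a limit and not a number, so this step gives a minimum size and not a full one: the limit of > 50000 nM in this assay, at which 1 of the 3 values shown sits.

Going by these compounds, whether the loss goes with the nitro group or with the furan ring remains open, and a furan-2-yl without the nitro group on this carbonyl would separate the two. Also open, on these data alone, is whether the pyridine nitrogen matters at all, a question that a plain phenyl at this place would address.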